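The source may report more compounds than this note shows. Statements on the series, on what has been measured and on what is new or still open speak of the compounds shown alone.

Measured compounds:
- compound 1 (`O=c1n(Cc2cc3cnccc3n2CCCC(F)(F)F)c2cnccc2n1C1CC1`) gives (> 50000 nM), a limit
- compound 2 (`NC(=O)CCCn1c(Cn2c(=O)n(C3CC3)c3ccncc32)cc2cc(Cl)ccc21`) gives (> 50000 nM), a limit

In an ADME assay on HeLa cells (Homo sapiens) for cytotoxicity, read by ATP content, with a stated time of 3 days (a higher number here means that more compound is tolerated, a lower number that less compound is tolerated), compound 1 stands only at a limit (> 50000 nM), and no number is known for it. Compound 2 is likewise a limit (> 50000 nM). Both compounds sit at the same ceiling (the limit of > 50000 nM in this assay, at which 2 of the 2 values shown sit).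

Compound 3 (`CS(=O)(=O)CCCn1c(Cn2c(=O)n(C3CC3)c3ccncc32)cc2cnccc21`) has methylsulfonyl in place of trifluoromethyl on a saturated chain carbon, three bonds along the chain from an aromatic nitrogen. For the measured compounds named here, no measured step bears on this change. In this assay no step beyond the scatter is expected in either direction for compound 3, an expectation resting on compound 1 and its limit (> 50000 nM). The expected step (a number no higher from compound 1 to compound 3 (the limit leaves the size open)) stays within the scatter. Compound 3 is estimated at (50000 nM), with an expected range from 25000 nM to 100000 nM and a limit the likeliest report.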

Compound 3, half-maximal cytotoxic concentration: > 50000 nM
Compound 3: no number, only a limit; the forecaster's own chance of this, stated with the estimate: 85%; the middle value lies on the limit itself.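

Compound 3 gives > 50000 nM, a limit. Compound 1 is also only a limit, so no step can be read from compound 1 to compound 3: the limit of > 50000 nM in this assay, at which 3 of the 3 values shown sit.

The compounds shown leave open whether methylsulfonyl in place of trifluoromethyl changes the tolerated concentration at all in this assay.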